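The source may report more compounds than this note shows. Statements on the series, on what has been measured and on what is new or still open speak of the compounds shown alone.

Measured so far in an assay on isolated protein for inhibition of serine/threonine-protein kinase 10 (Homo sapiens), read by thermal shift assay, tested at 10 uM; on this read-out higher numbers stand for stronger stabilisation of the target against heat and lower numbers for weaker stabilisation of the target:
- compound 1, `CC(C)(C)c1cc(NC(=O)Nc2ccc(Cl)cc2)n(-c2ccc(OC(F)(F)F)cc2)n1`, gives 0 degrees C
- compound 2, `CC(C)(C)c1cc(NC(=O)Nc2ccc(Cl)cc2)n(-c2ccc(S(C)(=O)=O)cc2)n1`, gives 4.1 degrees C

Compound 2 stands highest of the two numbers measured; its nearest neighbour is compound 1, and the step of a number 4.1 degrees C higher from compound 1 to compound 2 (beyond the scatter) separates them, a large change that comes from a single swap of one group on the aromatic ring that hangs off the shared core.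

Compound 3, `CC(C)(C)c1cc(NC(=O)Nc2ccc(Cl)cc2)n(-c2ccc(N)cc2)n1`, has not been measured. It differs from compound 2 by amino in place of methylsulfonyl on an aromatic carbon, that is, amino in place of methylsulfonyl at the same position on that ring. For the measured compounds named here, the only step measured so far, a number 4.1 degrees C higher from compound 1 to compound 2 (beyond the scatter), concerns this very position and shows that exchanging the group there can move the reading strongly. Going by the values given here, compound 3 loses the methylsulfonyl that compound 2 carries and gains a far smaller group, so a downward step is expected: a number 2.6 degrees C lower from compound 2 to compound 3 (beyond the scatter), with wide uncertainty because only the one step from compound 1 to compound 2 informs it. For compound 3 the estimate in this assay is 1.5 degrees C, with a range from -0.5 degrees C to 3.5 degrees C.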

Compound 3, shift of the target's melting temperature: 2 degrees C
For compound 3 the middle estimate is 0.50 degrees C below the measured one; the range from low to high includes it.
By their numbers in this assay, from the lowest: compound 1; then compound 3; then compound 2.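

In this assay this position now has three groups with readings, and the new one falls between the other two: a number 2.0 degrees C higher from compound 1 to compound 3 (beyond the scatter) while a number 2.1 degrees C lower from compound 2 to compound 3 (beyond the scatter). So the methylsulfonyl group is not the only group here that gives a reading clearly above that of compound 1, since an amino group of a single heavy atom, with no sulfur or oxygen, also does so, though not to the level of compound 2. The two groups that read above compound 1 also differ in their printed counts, with no hydrogen-bond donor and 2 acceptors on methylsulfonyl against 1 of each on amino, so a hydrogen-bond donor at this place is not needed for a reading above compound 1, and nothing available explains why these readings fall in this order.

The compounds shown leave open how a sulfonamide, a carboxylic acid or an acetamide would read at this same place, and so whether the reading follows the size of the group, the atoms it carries or something else. They also leave open whether this order of the three groups would hold if the chlorophenyl or tert-butyl groups on the shared core were exchanged.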